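Trading a Benzyl for a Phenyl Group

The source may hold more compounds than are shown below. What is called first, only, known or untested is meant among the compounds shown, and "the series" means these compounds.

In a functional assay on BT-474 cells (Homo sapiens) for inhibition, read by fluorescence, with a stated time of 72 h (on this read-out lower numbers stand for stronger inhibition of growth and higher numbers for weaker inhibition of growth), compound 1 (`N[C@H]1CC[C@H](Nc2nc(Nc3ccc(Cl)cc3)c3ncn(C4CCCCC4)c3n2)CC1`) gives 4100 nM and compound 2 (`CCCCn1cnc2c(NCc3cccc(Cl)c3)nc(N[C@H]3CC[C@H](N)CC3)nc21`) gives 4700 nM so the two stand level within the usual scatter. Compound 3 (`CCCCn1cnc2c(Nc3ccc(Cl)cc3)nc(N[C@H]3CC[C@H](N)CC3)nc21`) arises from compound 2 through one change (4-chlorophenyl in place of 3-chlorobenzyl on a nitrogen on an aromatic ring) with 4-chlorophenyl in place of 3-chlorobenzyl on a nitrogen on an aromatic ring. For the measured compounds named here, no measured pair shows this change alone, so the expectation is loose. Compound 1 also carries 4-chlorophenyl and gives 4100 nM in the same range. The expected step (a 1.3-fold lower number from compound 2 to compound 3 (0.13 log units; within the scatter)) therefore stays within the scatter. For compound 3 the estimated value is 3500 nM (range 1200 nM to 10000 nM).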

Compound 3, concentration for 50% growth inhibition: 7300 nM
Beside the measured number, compound 3's estimate is 2.1-fold (0.32 log units) below it; low and high end bracket the measured number.
By their numbers in this assay, from the lowest: compounds 1, 2 and 3 (each within the scatter of the next).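

In this assay, swapping the group on a nitrogen on an aromatic ring gives a 1.6-fold higher number from compound 2 to compound 3 (0.19 log units; within the scatter) and so leaves 4-chlorophenyl and 3-chlorobenzyl level here. Changing a second place, with butyl in place of cyclohexyl on an aromatic nitrogen, gives a 1.8-fold higher number from compound 1 to compound 3 (0.25 log units; within the scatter) and is equally small. No evidence is available to explain either result.

The swap alters both the linker and the chlorine's location, and these compounds cannot separate the two. From the compounds shown here alone, whether an amine on the phenyl ring or a longer chain in place of butyl would shift growth inhibition beyond the scatter remains open.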